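From 2-acetamidoethyl to cyclopropyl on an aromatic nitrogen

The compounds below may be only part of what the source reports. "The series", "measured", "known", "first", "only" and "open" are said of these compounds alone.

Compound 1 `CCN1CCN(c2nc(C)nc3c2nc(-c2ccccc2Cl)n3C)CC1`: 7%
Compound 2 `CC(=O)NCCn1c(-c2ccccc2Cl)nc2c(N3CCN(C)CC3)nc(C)nc21`: 0%

In an ADME assay (liver) for metabolic stability, with Liver microsome (Homo sapiens) as the target, read by LC-MS, using microsomes, with a stated time of 30 min, tested at 4 uM (on this read-out lower numbers stand for a less stable compound and higher numbers for a more stable compound), compound 2 gives 0% and lies within the usual scatter of compound 1, so both sit near the bottom of the scale. Compound 3 `Cc1nc(N2CCN(C)CC2)c2nc(-c3ccccc3Cl)n(C3CC3)c2n1` carries cyclopropyl in place of 2-acetamidoethyl on an aromatic nitrogen and is otherwise unchanged from compound 2. Going by the values given here, no measured pair isolates this change. With compound 1 also low at 7%, only a small upward shift is expected, probably within the scatter. The estimated step of a number 8 percentage points higher from compound 2 to compound 3 (within the scatter) is therefore modest. For compound 3 the expected value is 8%, with an estimated range of 0% to 25%.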

Compound 3, percent of the compound remaining: 31%
Estimate against measurement, compound 3: 23 percentage points below; the measured number lies above the stated range.
By their numbers in this assay, from the lowest: compounds 2 and 1 (each within the scatter of the next); then compound 3.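

In this assay, cyclopropyl in place of 2-acetamidoethyl on the aromatic nitrogen brings a large gain (a number 31 percentage points higher from compound 2 to compound 3 (beyond the scatter)). This shows that the group at this position can lift a compound clear of the bottom of the scale, which compound 1 and compound 2, differing in more than one place, could not show. Nothing measured here explains the rise. Going by these compounds, whether the gain comes from the cyclopropyl ring itself or simply from losing 2-acetamidoethyl stays open. An isopropyl or cyclobutyl group on the same nitrogen would help separate the two.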